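Para-substituent swap on the benzamide of compound 1

The source may hold more compounds than are shown below. What is called first, only, known or untested is meant among the compounds shown, and "the series" means these compounds.

Compound 1 `Cc1ccc(C(=O)Nc2nc(Cl)c3cn(C)nc3n2)cc1` is one of two compounds read in an assay on CHO cells for displacement of a labelled ligand from adenosine receptor A1 (Homo sapiens), read by scintillation counting, with a stated time of 3 h; on this read-out higher numbers stand for weaker inhibition and lower numbers for stronger inhibition. For compound 1 the reported figure is a limit of the assay, > 100000 nM, and not a number. Compound 2 `Cc1ccc(C(=O)Nc2nc(Cl)c3cn(CC(C)(C)C)nc3n2)cc1` carries tert-butyl in place of hydrogen on a saturated chain carbon bound to an aromatic nitrogen, and in this assay compound 2 gives 11100 nM. That single measured step, an at least 9.0-fold lower number from compound 1 to compound 2 (0.95 log units; beyond the scatter), reads as at least modest; its true size is bounded only by the limit of > 100000 nM in this assay, at which 1 of the 2 values shown sits.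

Compound 3 `Cn1cc2c(Cl)nc(NC(=O)c3ccc(F)cc3)nc2n1` keeps the core and the nitrogen substituent of compound 1 and differs only in fluoro in place of methyl on an aromatic carbon, on an aromatic carbon of a six-membered aromatic ring of carbon only, para to a large group; cut one bond further out it reads 4-methylphenyl to 4-fluorophenyl. For the measured compounds named here, no measured step touches that ring: the only step, an at least 9.0-fold lower number from compound 1 to compound 2 (0.95 log units; beyond the scatter), changes the group on the aromatic nitrogen. The expected step of a number no higher from compound 1 to compound 3 (the limit leaves the size open) is therefore none beyond the scatter. Compound 3 is estimated at 100000 nM in this assay, between 30000 nM and 300000 nM.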

Compound 3, inhibition constant: > 100000 nM
Compound 3: a limit, no number; the forecaster's own chance of this, stated with the estimate: 70%; the middle value sits exactly at the limit.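

For the compounds shown here, compound 1 and compound 3 both stand at a limit in this assay and neither gives a number, so no step between them can be read, because: the limit of > 100000 nM in this assay, at which 2 of the 3 values shown sit.

Still open, on these data alone, is whether 4-fluorophenyl and 4-methylphenyl differ at all in this read-out, either on the core of compound 1 or with the nitrogen substituent of compound 2.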